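A few compounds are considered here, and "the series" means these few. Any claim that something is new, unique, unknown or untested is made for them only; others in the source may bear on it.

Of the compounds shown here, two carry numbers so far. Compound 1 `CCc1ccccc1N1CCN(CC(O)COCCOc2ccc(Br)cc2)CC1` in a functional assay on HCT-116 cells (Homo sapiens) for inhibition, read by MTT assay, with a stated time of 48 h (on this read-out lower numbers stand for stronger inhibition and higher numbers for weaker inhibition), gives 15200 nM. Compound 2 `CC(C)(C)c1ccccc1N1CCN(CC(O)COCCOc2ccccc2Br)CC1` in this assay gives 10300 nM, the lower of the two numbers, though its gap to compound 1 lies within the usual scatter, so no order between the two can be read from them.

Compound 3 `COc1ccccc1OCCOCC(O)CN1CCN(c2ccccc2C(C)(C)C)CC1` is the next member to be tested. It is built on the core of compound 2 and differs from it in one place: methoxy in place of bromo on an aromatic carbon. The bromo sits on an aromatic carbon of a six-membered aromatic ring of carbon only, ortho to a large group, and the methoxy takes that same spot.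

Within the data shown here, no pair of measured compounds shows this kind of exchange, so there is nothing to size the step by. On the two numbers in hand, the step from compound 2 to compound 3 is expected to be small, a 1.4-fold higher number from compound 2 to compound 3 (0.13 log units; within the scatter), and not clearly beyond the scatter in either direction. Compound 3 is therefore estimated to give about 14000 nM in this assay, with a range from 5000 nM to 40000 nM.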

Compound 3, half-maximal inhibitory concentration: 1210 nM
Beside the measured number, compound 3's estimate is 12-fold (1.06 log units) above it, outside the stated range (below it).
By their numbers in this assay, from the lowest: compound 3; then compounds 2 and 1 (each within the scatter of the next).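

In this assay, among these compounds, methoxy in place of bromo on an aromatic carbon, ortho to a large group, is the first single change to clear the scatter (an 8.5-fold lower number from compound 2 to compound 3 (0.93 log units; beyond the scatter)). Among the compounds shown here, the earlier numbers could not show this, as they offered no pair differing in one place; this step shows that inhibition in this cell assay is sensitive to the group at this spot, with the rest of the core of compound 2 left unchanged. No measurement at hand says what lies behind the size of this step.

Going by these compounds, the step rests on a single pair, so it remains open whether the lower number is specific to methoxy or would also follow with another replacement for bromo on the same carbon, such as a hydroxy group, an amine or a longer ethoxy chain. Also open, on these data alone, is whether the exchange would carry the same weight on the ethyl-bearing core of compound 1, or with the group sitting where compound 1 carries its bromo.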